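The compounds below may be only part of what the source reports. "The series", "measured", "known", "first", "only" and "open" are said of these compounds alone.

Of the compounds shown here, two with a shared core have been measured in a functional assay on EA.hy 926 cells (Homo sapiens) for cytotoxicity, read by MTT assay, with stated times of 24 h and 12 h, tested at 100 uM; on this read-out lower numbers stand for a weaker effect and higher numbers for a stronger effect at the one concentration tested. Compound 1 `COc1cc(/C=C/C(=O)O)ccc1OC(=O)c1nc(C)c(C)nc1C` gives 55.4% in this assay. Compound 2 `CCOC(=O)/C=C/c1ccc(OC(=O)c2nc(C)c(C)nc2C)c(O)c1` gives 375%, so compound 1 holds the lower of the two numbers, and the two values stand far apart, well beyond the scatter. Compound 1 and compound 2 differ in more than one place. This gap cannot be tied to a single change.

Compound 3 `COc1cc(/C=C/C(=O)O)cc(OC)c1OC(=O)c1nc(C)c(C)nc1C` has not yet been measured. It differs from compound 1 in one place: methoxy in place of hydrogen on an aromatic carbon. Among the compounds with values here, no measured pair shows what a methoxy entering at such a site does in this assay, so no step size can be read from the data. The step of a number 4.6 percentage points higher from compound 1 to compound 3 (within the scatter) is therefore expected to be small, likely within the scatter, with the direction left open. Compound 3 is estimated at 60% in this assay, with a range from 25% to 140%.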

Compound 3, a percentage reported as activity, at one concentration (the size of the read-out at that concentration, not a potency): 163%
For compound 3 the middle estimate is 103 percentage points below the measured one; measured number outside the range, above it.
By their numbers in this assay, from the lowest: compound 1; then compound 3; then compound 2.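

Within the data shown here, the pair gives the first single-change step: methoxy in place of hydrogen on an aromatic carbon, ortho to a large group and meta to both a 2-carboxyethenyl group and a methoxy group, gives a number 107.6 percentage points higher from compound 1 to compound 3 (beyond the scatter) in this assay. This position on the shared core is therefore not a silent one, as one small group entering there is enough to produce a large upward step at the one concentration tested. No available data explain why the number rises at this site.

What an amine or a longer ethoxy chain would do at this same aromatic carbon remains open, so the compounds shown cannot say whether this step is particular to methoxy. Also open, from the compounds shown here alone, is whether methoxy would give a similar step at another position on the core.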